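Swapping Octyl for Cyclopropyl: What Cytotoxicity to Expect

A few compounds are considered here, and "the series" means these few. Any claim that something is new, unique, unknown or untested is made for them only; others in the source may bear on it.

Measured compounds:
compound 1, `CCCCCCCCc1cn(C(c2ccccc2)c2cc3cc(Br)ccc3nc2OC)nn1`, giving 0.1%
compound 2, `CCOC(=O)c1cn(C(c2ccccc2)c2cc3cc(Br)ccc3nc2OC)nn1`, giving -3.67%
compound 3, `COc1nc2ccc(Br)cc2cc1C(c1ccccc1)n1cc(-c2ccc(F)cc2)nn1`, giving 4.27%

In an ADME assay on HeLa cells (Homo sapiens) for cytotoxicity, read by sulforhodamine B assay, with a stated time of 48 h, tested at 10 uM (on this read-out lower numbers stand for less inhibition and higher numbers for more inhibition at the one concentration tested (going by the name of the read-out)), compound 1 gives 0.1%, the second highest of the three numbers. Its nearest neighbour is compound 2 with -3.67%, and the furthest is compound 3 with 4.27%; both of these gaps sit within the scatter, so no order among the three can be read from them.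

The unmeasured compound 4, `COc1nc2ccc(Br)cc2cc1C(c1ccccc1)n1cc(C2CC2)nn1`, departs from compound 1 in one place: cyclopropyl in place of octyl on an aromatic carbon. The same position on the shared core was varied in every measured step. Those steps were a number 3.8 percentage points lower from compound 1 to compound 2 (within the scatter), a number 4.2 percentage points higher from compound 1 to compound 3 (within the scatter) and a number 7.9 percentage points higher from compound 2 to compound 3 (within the scatter), and none of them left the scatter. Three quite different groups at that position all gave near-zero readings, which gives no ground to expect cyclopropyl to behave otherwise. Compound 4 is therefore expected to show a number 0.4 percentage points higher from compound 1 to compound 4 (within the scatter), a move that would not rise above the scatter. Taking the measured compounds together, compound 4 is estimated at 0.5%, with a range from -8% to 10%.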

Compound 4, a percentage reported as inhibition, at one concentration (the size of the read-out at that concentration, not a potency): -5.84%
Beside the measured number, compound 4's estimate is 6.3 percentage points above it; the range from low to high includes it.
By their numbers in this assay, from the lowest: compounds 4, 2, 1 and 3 (each within the scatter of the next, the first and the last beyond it).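

In this assay, replacing octyl with cyclopropyl gives a number 5.9 percentage points lower from compound 1 to compound 4 (within the scatter), and replacing ethoxycarbonyl with cyclopropyl gives a number 2.2 percentage points lower from compound 2 to compound 4 (within the scatter), so neither change can be told apart from repeat variation. Going by these compounds alone, replacing 4-fluorophenyl with cyclopropyl, however, gives a number 10.1 percentage points lower from compound 3 to compound 4 (beyond the scatter), a modest step but the only one at this position on the five-membered aromatic ring to leave the scatter, whereas all three earlier steps stayed inside it; the two ring-bearing groups, cyclopropyl and 4-fluorophenyl, are therefore the one pair here that this read-out separates, while the steps from octyl and ethoxycarbonyl to either of them do not form a trend. Nothing available explains why this single pair separates.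

The compounds shown leave open whether a basic amine, a carboxylic acid or a longer chain at this same position would move the number further from the others or leave it in the same narrow band. They also leave open whether the gap between compound 3 and compound 4 would persist at other concentrations, since only one concentration is reported.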